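Hydroxy to Amino Swap on Two Azole-Bearing Phenyl Cores

The source may report more compounds than this note shows. Statements on the series, on what has been measured and on what is new or still open speak of the compounds shown alone.

Measured so far:
compound 1 `Oc1ccc(Cl)cc1-c1nnc[nH]1`, 600 nM
compound 2 `Nc1ccc(Cl)cc1-c1nnc[nH]1`, 35 nM
compound 3 `Oc1ccccc1-c1nnn[nH]1`, 700000 nM

In an assay on cells for inhibition of Indoleamine 2,3-dioxygenase 1 (Homo sapiens), read by HPLC, with a stated time of 20 min (a higher number here means a weaker inhibitor, a lower number a stronger inhibitor), compound 1 gives 600 nM, compound 2 gives 35 nM and compound 3 gives 700000 nM. Compound 3 stands highest of the three; its nearest neighbour is compound 1, and the difference between the two cores is not broken down here.

Going by the values given here, the one counted step is a 17-fold lower number from compound 1 to compound 2 (1.23 log units; beyond the scatter). The change behind it is amino in place of hydroxy on an aromatic carbon.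

Compound 4 `Nc1ccccc1-c1nnn[nH]1` is not yet measured. It differs from compound 3 as amino in place of hydroxy on an aromatic carbon. This is the same kind of change as that from compound 1 to compound 2, not the same: in compound 1 the place is also para to a chloro group (1 heavy atom), and in compound 3 it is not. Whether the step carries over from one core to the other cannot be read from two measured pairs.

Expectation: compound 4 is estimated to land near 50000 nM in this assay, between 8000 nM and 300000 nM. From the compounds shown here alone, that estimate means a step of a 14-fold lower number from compound 3 to compound 4 (1.15 log units; beyond the scatter), taken beside a 17-fold lower number from compound 1 to compound 2 (1.23 log units; beyond the scatter) and widened because compound 3 starts from 700000 nM, where the direction of the swap is carried over but its size on this core is unknown.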

Compound 4, half-maximal inhibitory concentration: 5800 nM
The estimate for compound 4 lay 8.6-fold (0.94 log units) above the measured number, and the stated range ends above it.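

In this assay amino in place of hydroxy on an aromatic carbon gives a 120-fold lower number from compound 3 to compound 4 (2.08 log units; beyond the scatter) and so lowers the number on the second core as well. The direction of the change carries over between the two cores, but its size does not: the same change on two cores in this assay, a 17-fold lower number (1.23 log units; beyond the scatter) from compound 1 to compound 2 and a 120-fold lower number (2.08 log units; beyond the scatter) from compound 3 to compound 4, 7.0-fold (0.85 log units) apart, beyond the scatter of two such steps.

Two pairs do not show which difference between the cores, the chloro group or the attached ring, sets the size of the step, and they give no rule for predicting that size on a third core.

Going by these compounds alone, no pair here isolates the chloro group or the attached ring, so the effect of each alone on the number, and on the size of the swap, remains open. Also open, from the compounds shown here alone, is how other groups would behave at the place held by hydroxy or amino, such as a methylamino group, an acetamide or a carboxylic acid, and whether a fluoro or methoxy group in the position of the chloro group would keep the step seen from compound 1 to compound 2.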